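This account rests on a few compounds, and the source may have more. Where it says the series, first, only, none or still open, it means among the compounds named here.

Working notes on the series

Measured compounds:
- compound 1, `Cc1ccc(SCc2ccc(/C=C/C(=O)Nc3ccccc3N)cc2)cc1`, in a functional assay on SMMC-7721 cells (Homo sapiens) for inhibition, read by CCK-8 assay, with a stated time of 72 h, tested at 2 uM (on this read-out higher numbers stand for more inhibition of growth at the one concentration tested and lower numbers for less inhibition of growth), gives 22%
- compound 2, `Nc1ccccc1NC(=O)/C=C/c1ccc(CSc2ccc(Cl)cc2)cc1`, in this assay gives 15.2%
- compound 3, `Cc1cc(C)cc(SCc2ccc(/C=C/C(=O)Nc3ccccc3N)cc2)c1`, in this assay gives 8.61%

Compound 3 has the lowest of the three numbers in this assay. Its nearest neighbour is compound 2, and the step of a number 6.6 percentage points lower from compound 2 to compound 3 (within the scatter) lies within the scatter. Its furthest neighbour is compound 1, and the step of a number 13.4 percentage points lower from compound 1 to compound 3 (beyond the scatter) is a modest one beyond the scatter. Compound 3 is therefore not separated from compound 2 on the numbers, only from compound 1.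

The next compound, compound 4, `Nc1ccccc1NC(=O)/C=C/c1ccc(CSc2cccc3ccccc23)cc1`, has not yet been measured in this assay. Its change from compound 3 is naphthalen-1-yl in place of 3,5-dimethylphenyl on a sulfur. The two measured steps that bear on it are those that also exchange the aryl group on the sulfur: a number 13.4 percentage points lower from compound 1 to compound 3 (beyond the scatter) and a number 6.6 percentage points lower from compound 2 to compound 3 (within the scatter). Going by the values given here, both of these moved the number downward, one beyond and one within the scatter, and no measured pair exchanges a phenyl for a fused bicyclic group. A step of roughly the scatter or less, in either direction, is expected in this assay; the step of a number 3.4 percentage points higher from compound 3 to compound 4 (within the scatter) is the estimate taken here. For compound 4 the expected value in this assay is 12%, with a range from 0% to 28%.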

Compound 4, percent growth inhibition at one concentration: 3.7%
Compound 4: middle estimate off by 8.3 percentage points, on the high side; the range from low to high includes it.
By their numbers in this assay, from the lowest: compounds 4, 3, 2 and 1 (each within the scatter of the next, the first and the last beyond it).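

At the aryl group on the sulfur, the series now includes a fused bicyclic group, and in this assay the step of a number 4.9 percentage points lower from compound 3 to compound 4 (within the scatter) does not separate naphthalen-1-yl from 3,5-dimethylphenyl. The other two exchanges do give a separation: a number 11.5 percentage points lower from compound 2 to compound 4 (beyond the scatter) and a number 18.3 percentage points lower from compound 1 to compound 4 (beyond the scatter) place naphthalen-1-yl apart from both 4-chlorophenyl and 4-methylphenyl, whereas 3,5-dimethylphenyl in compound 3 was separated only from the 4-methylphenyl of compound 1. No measurement at hand bears on the reason for these differences.

Open, from the compounds shown here alone, is whether the group on the sulfur has to be an aromatic carbon ring at all: a pyridine ring, a cyclohexyl group or a butyl chain in that place could fall near compound 1, near compound 4 or outside both. Also open, going by these compounds, is how far these numbers carry beyond the single concentration tested, as a full concentration-response curve could rank the compounds differently.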